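From 2-Hydroxyethyl to 3-Hydroxypropyl in Compound 1

A few compounds are considered here, and "the series" means these few. Any claim that something is new, unique, unknown or untested is made for them only; others in the source may bear on it.

Compound 1 `COc1cc(/C=C/C(=O)/C=C(/C=C/c2ccc(O)c(OC)c2)NCCO)ccc1O` gives 8140 nM
Compound 2 `COc1cc(/C=C/C2=CC(=O)CC(c3ccc(O)c(OC)c3)N2CCCO)ccc1O` gives 58900 nM
Compound 3 `COCCCN1C(/C=C/c2ccc(O)cc2)=CC(=O)CC1c1ccc(O)cc1` gives 25800 nM

These numbers come from a physicochemical assay for solubility, using the shake flask method, in phosphate buffer, with a stated time of 90 min, at pH 6.8 (on this read-out higher numbers stand for higher solubility and lower numbers for lower solubility), and compound 1 stands lowest of the three, with compound 3 and compound 2 both higher by more than the usual scatter of repeated measurements. Compound 4 `COc1cc(/C=C/C(=O)/C=C(/C=C/c2ccc(O)c(OC)c2)NCCCO)ccc1O` has not yet been measured. It keeps the core of compound 1 and differs only in the side chain. The difference is hydroxymethyl in place of hydroxy on a saturated chain carbon, two bonds along the chain from an amine nitrogen and in words it is hydroxymethyl in place of hydroxy on a saturated chain carbon, two bonds along the chain from an amine nitrogen. Read one bond further out, this is 2-hydroxyethyl to 3-hydroxypropyl.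

Among the compounds with values here, no two measured compounds differ in one place only, so the data give no direct size for this change. Compound 2 also carries 3-hydroxypropyl and gives 58900 nM but its core differs, so that value cannot be credited to the chain. Within the data shown here, the expectation therefore rests on compound 1 at 8140 nM as the only measured compound sharing this core. In this assay, going by these compounds, no step beyond the scatter is expected, and the direction remains open. The estimate is a 1.2-fold lower number from compound 1 to compound 4 (0.07 log units; within the scatter) and this expected size lies within the scatter. Compound 4 is expected at 7000 nM (estimated range 2500 nM to 20000 nM).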

Compound 4, solubility: 25400 nM
The estimate for compound 4 lay 3.6-fold (0.56 log units) below the measured number; measured number above the stated range.
By their numbers in this assay, from the lowest: compound 1; then compounds 4 and 3 (each within the scatter of the next); then compound 2.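

In this assay, within the data shown here, the change from 2-hydroxyethyl to 3-hydroxypropyl on the shared core gives a 3.1-fold higher number from compound 1 to compound 4 (0.49 log units; beyond the scatter) and this is the first measured size and direction for any change in this set. The earlier compounds shown here could not show this, since none of them differed from another in one place only, and the high number of compound 2 could not be credited to its chain. The position on the saturated chain carbon, two bonds along the chain from an amine nitrogen, therefore does respond to hydroxymethyl in place of hydroxy, at least on the core of compound 1, though nothing measured here accounts for the rise.

Going by these compounds, a single pair gives one step on one core, so whether the same change would give a similar step on another core remains unknown. The compounds shown also leave open what a longer chain, a chain ending in an amine or a carboxylic acid in place of the hydroxy group would do at this position.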